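A few compounds are considered here, and "the series" means these few. Any claim that something is new, unique, unknown or untested is made for them only; others in the source may bear on it.

Compound 1 `CCOC(=O)C1=C(C)N/C(=C/c2cc(C)n(-c3ccc(CN(C)C)cc3)c2C)C1=O` is the most soluble of the three measured compounds in a physicochemical assay for solubility, read by nephelometry, in phosphate buffer, measured as kinetic solubility, at pH 6.5 (on this read-out higher numbers stand for higher solubility and lower numbers for lower solubility), where compound 1 gives 12.5 ug/mL. Compound 2 `CCOC(=O)C1=C(O)/C(=C\c2cc(C)n(-c3ccc(F)cc3)c2C)N=C1C` in this assay gives 3.1 ug/mL, and compound 3 `CCOC(=O)C1=C(C)N/C(=C/c2cc(C)n(Cc3ccc(C(F)(F)F)cc3)c2C)C1=O` in this assay gives 1.6 ug/mL; both of these numbers lie beyond the scatter below the number for compound 1, and compound 3 stands furthest from it.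

Compound 4 `CCOC(=O)C1=C(C)N/C(=C/c2cc(C)n(-c3ccc(CN4CCCCC4)cc3)c2C)C1=O` has not yet been measured. It differs from compound 1 in one place: piperidin-1-yl in place of dimethylamino on a saturated chain carbon bound to an aromatic carbon. Among the measured compounds shown here, no measured pair in this set differs by this same exchange. Any expectation therefore rests on the position of compound 1 alone and on the change itself. The author expects that the number for compound 4 in this assay will sit somewhat lower than that of compound 1, with the step from compound 1 to compound 4 estimated as a 2.1-fold lower number from compound 1 to compound 4 (0.32 log units; beyond the scatter), a downward move that could still fall close to the usual scatter. On that basis compound 4 is estimated at 6 ug/mL, within a range from 2 ug/mL to 18 ug/mL.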

Compound 4, solubility: 12.5 ug/mL
Compound 4: the middle estimate sits 2.1-fold (0.32 log units) below what was measured, and the stated range covers the measured number.
By their numbers in this assay, from the lowest: compounds 3 and 2 (each within the scatter of the next); then compounds 1 and 4 (each within the scatter of the next).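

In this assay, among the compounds shown here, placing piperidin-1-yl in place of dimethylamino on a saturated chain carbon bound to an aromatic carbon gives no change at the digits printed from compound 1 to compound 4 (within the scatter), the first one-place step in this set. At this place, then, a group with one six-membered non-aromatic ring stands where a group with no ring stood, and the read-out does not separate the two compounds. Nothing given here bears on the reason for this match.

The compounds shown leave open whether a morpholine ring, a primary amine or a carboxylic acid on that same carbon would read alike, and whether a longer chain carrying the piperidin-1-yl group would do so. As far as these compounds go, the exchange is also seen only once, on the core of compound 1, so its outcome on any other core remains open.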